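From a hydroxypyrrolidine to a longer carbamoyl side chain

This account rests on a few compounds, and the source may have more. Where it says the series, first, only, none or still open, it means among the compounds named here.

Of the compounds shown here, three sharing one core have been read in a functional assay on HeLa cells (Homo sapiens) for antiproliferative activity, read by CCK-8 assay, with a stated time of 48 h; a lower number here means a stronger inhibitor, a higher number a weaker inhibitor. Compound 3 `COc1ccc(/C=C\c2cc(OC)c(OC)c(OC)c2)cc1OCc1ccc(CN2CC[C@@H](O)C2)cc1` gives > 10000 nM, which is a limit of the assay and not a number. It is the limit of > 10000 nM in this assay, at which 1 of the 3 values shown sits. Compound 2 `COc1ccc(/C=C\c2cc(OC)c(OC)c(OC)c2)cc1OCc1ccc(CNCCNC(C)=O)cc1`, with (2-acetamidoethyl)amino at the same place, gives 6400 nM.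

The next structure is compound 4 `COc1ccc(/C=C\c2cc(OC)c(OC)c(OC)c2)cc1OCc1ccc(CN2CCCCC2C(=O)NCCN)cc1`. It carries 2-((2-aminoethyl)carbamoyl)piperidin-1-yl in place of 3-hydroxypyrrolidin-1-yl on a saturated chain carbon bound to an aromatic carbon.

Among the measured compounds shown here, the one measured step at this place is an at least 1.5-fold higher number from compound 2 to compound 3 (0.19 log units; that floor lies within the scatter), and it fixes only a floor, so it offers no size to carry over. The better guide is compound 1 `COc1ccc(/C=C\c2cc(OC)c(OC)c(OC)c2)cc1OCc1ccc(CN2CCCCC2C(=O)NCCNC(=O)OC(C)(C)C)cc1`, which holds the entering group with its terminal amine capped. In this assay compound 1 gives 2000 nM, and on that value a move to a lower number is expected for the new side chain. For the measured compounds named here, the size stays loose, as the starting point is a limit and the free amine itself has no measured counterpart. The expected change is an at least 3.3-fold lower number from compound 3 to compound 4 (0.52 log units; beyond the scatter). Compound 4 is estimated at 3000 nM, with an expected range from 900 nM to 9000 nM.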

Compound 4, half-maximal inhibitory concentration: 7300 nM
Estimate against measurement, compound 4: 2.4-fold (0.39 log units) below; the range from low to high includes it.
By their numbers in this assay, from the lowest: compound 1; then compounds 2 and 4 (each within the scatter of the next). At a limit, above all of these: compound 3.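

In this assay, among the compounds shown here, the one step here that lies beyond the scatter concerns the end of the new side chain: a 3.7-fold higher number from compound 1 to compound 4 (0.56 log units; beyond the scatter). At this position, then, the tert-butoxycarbonyl cap on the terminal amine of the 2-((2-aminoethyl)carbamoyl)piperidin-1-yl group goes with a stronger result than the free amine, while the free-amine side chain cannot be told apart from the open-chain (2-acetamidoethyl)amino group: a 1.1-fold higher number from compound 2 to compound 4 (0.06 log units; within the scatter). The difference from the 3-hydroxypyrrolidin-1-yl group can be given only as a floor, an at least 1.3-fold lower number from compound 3 to compound 4 (0.13 log units; that floor lies within the scatter), because compound 3 is a limit of the assay and not a number: the limit of > 10000 nM in this assay, at which 1 of the 4 values shown sits.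

The compounds shown leave open whether a small acetyl group on the terminal amine of the piperidine side chain would match the tert-butoxycarbonyl cap of compound 1 or stay level with compound 4. They also do not tell whether a longer chain carrying that amine, or a carboxylic acid in its place, would move the number in this assay.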